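This account rests on a few compounds, and the source may have more. Where it says the series, first, only, none or still open, it means among the compounds named here.

Three compounds in this series share a core in which a carbonyl carbon carries an aromatic ring, and the ring is what varies. Compound 1, `CN(C)CCC(NC(=O)c1ccc(C(F)(F)F)cc1)c1ccc(Cl)cc1`, gives 77.6 nM in an assay on NIH3T3 cells with Urotensin-2 receptor (Homo sapiens) as the target; a lower number here means that less compound is needed, a higher number that more compound is needed for the effect. Compound 2, `CN(C)CCC(NC(=O)c1ccc(Oc2ccccc2)cc1)c1ccc(Cl)cc1`, gives 66.1 nM. For the measured compounds named here, the only step measured between neighbours, a 1.2-fold lower number from compound 1 to compound 2 (0.07 log units; within the scatter), shows that one group in place of another on that ring made no difference beyond the scatter. Compound 3, `Cc1ccc(C(=O)NC(CCN(C)C)c2ccc(Cl)cc2)c(C)c1`, gives 1550 nM, the highest of the three numbers, well above both compound 1 and compound 2.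

Compound 4, `CN(C)CCC(NC(=O)c1ccccc1)c1ccc(Cl)cc1`, takes the step (phenyl in place of 2,4-dimethylphenyl on a carbonyl carbon). Going by the values given here, no measured step removes methyl groups from the ring, so the step from compound 1 to compound 2 bears on it only loosely: it says that exchanging one ring substituent for another need not matter, while the gap between compound 3 and the other two shows that the ring pattern can matter a great deal. The estimate for compound 4 is a 3.9-fold lower number from compound 3 to compound 4 (0.59 log units; beyond the scatter), placing it between compound 3 and compound 1, at 400 nM with a range from 100 nM to 2000 nM.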

Compound 4, half-maximal effective concentration: 1410 nM
Compound 4: the middle estimate sits 3.5-fold (0.55 log units) below what was measured; the range from low to high includes it.
By their numbers in this assay, from the lowest: compounds 2 and 1 (each within the scatter of the next); then compounds 4 and 3 (each within the scatter of the next).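

Phenyl in place of 2,4-dimethylphenyl on a carbonyl carbon makes no difference beyond the scatter in this assay (a 1.1-fold lower number from compound 3 to compound 4 (0.04 log units; within the scatter)), so the two methyl groups neither help nor harm here. The unsubstituted ring also gives compound 1 and compound 2 a direct reference point: hydrogen in place of phenoxy gives a large change (a 21-fold higher number from compound 2 to compound 4 (1.33 log units; beyond the scatter)), and hydrogen in place of trifluoromethyl gives another (an 18-fold higher number from compound 1 to compound 4 (1.26 log units; beyond the scatter)), so among these four compounds only phenoxy and trifluoromethyl go with the low numbers. No measurement here explains why these two groups differ from the methyl pair.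

On these data alone, whether a single methyl, a methoxy, an amine or a carboxylic acid on the ring would track with phenoxy and trifluoromethyl remains open. So does whether the effect of either group depends on where it sits on the ring.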